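Indazole in place of fluoropyridine: a clearance estimate

The source may hold more compounds than are shown below. What is called first, only, known or untested is meant among the compounds shown, and "the series" means these compounds.

Measured compounds:
compound 1 `COCC#Cc1cc(C(O)(C(F)(F)F)C(F)(F)F)cnc1N1CCN(S(=O)(=O)c2ccc(N)nc2)CC1` gives 15 mL.min-1.g-1 in an ADME assay (liver) for metabolic stability, with Liver microsome (Homo sapiens) as the target, using microsomes and NADPH, with a stated time of 30 min, tested at 1 uM; on this read-out higher numbers stand for fast clearance and lower numbers for slow clearance;
compound 2 `Nc1ccc(S(=O)(=O)N2CCN(c3ncc(C(O)(C(F)(F)F)C(F)(F)F)cc3-c3cnccc3F)CC2)cn1` gives 17 mL.min-1.g-1 in this assay;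
compound 3 `Nc1ccc(S(=O)(=O)N2CCN(c3ncc(C(O)(C(F)(F)F)C(F)(F)F)cc3-c3cncc(F)c3)CC2)cn1` gives 24 mL.min-1.g-1 in this assay.

All three share one core and differ only in the group on the aromatic carbon. The steps are small: a 1.1-fold higher number from compound 1 to compound 2 (0.05 log units; within the scatter), a 1.6-fold higher number from compound 1 to compound 3 (0.20 log units; within the scatter) and a 1.4-fold higher number from compound 2 to compound 3 (0.15 log units; within the scatter), so compound 3 sits with the others inside the usual scatter. Compound 4 `Nc1ccc(S(=O)(=O)N2CCN(c3ncc(C(O)(C(F)(F)F)C(F)(F)F)cc3-c3ccc4[nH]ncc4c3)CC2)cn1` carries the change (1H-indazol-5-yl in place of 5-fluoropyridin-3-yl on an aromatic carbon). Among the measured compounds shown here, no measured step bears on an indazole; the steps seen so far all stayed within scatter, which suggests the change would not move the number beyond scatter. Compound 4 is therefore expected to give 25 mL.min-1.g-1 in this assay, with a range from 10 mL.min-1.g-1 to 60 mL.min-1.g-1. This estimate means a step of a 1.0-fold higher number from compound 3 to compound 4 (0.02 log units; within the scatter).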

Compound 4, intrinsic clearance in microsomes: 27 mL.min-1.g-1
Compound 4: middle estimate off by 1.1-fold (0.03 log units), on the low side; the measured number falls inside the stated range.
By their numbers in this assay, from the lowest: compounds 1, 2, 3 and 4 (each within the scatter of the next).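

Among the compounds shown here, the position on the aromatic carbon tolerates 1H-indazol-5-yl, the only group here with a hydrogen-bond donor and a five-membered aromatic ring, with every step in this assay staying within the scatter (a 1.1-fold higher number from compound 3 to compound 4 (0.05 log units; within the scatter) and a 1.6-fold higher number from compound 2 to compound 4 (0.20 log units; within the scatter) and a 1.8-fold higher number from compound 1 to compound 4 (0.26 log units; within the scatter)). So four quite different groups at this place give clearance numbers that cannot be told apart. Nothing available explains this result.

Still open, on these data alone, is whether an amine or a carboxylic acid at this place would move the number beyond the scatter.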